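Permeability notes on the aminoquinoline series: step to compound 4

The compounds below may be only part of what the source reports. "The series", "measured", "known", "first", "only" and "open" are said of these compounds alone.

In an ADME assay for permeability, using PAMPA, with a stated time of 30 min, at pH 7.4 (a higher number here means that the compound crosses the layer faster, a lower number that the compound crosses the layer more slowly), compound 1 `COc1cccc(CNCCCNc2ccnc3cc(-c4ccc(C(F)(F)F)cc4)ccc23)c1O` gives 237 10^-6 cm/s and compound 2 `COc1cccc(CNCCCNc2ccnc3cc(-c4ccccc4)ccc23)c1O` gives 237 10^-6 cm/s; the step of no change at the digits printed from compound 1 to compound 2 (within the scatter) is within the scatter. Compound 3 `COc1cccc(CNCCCNc2ccnc3cc(Cc4ccc(C#N)cc4)ccc23)c1O` gives 23 10^-6 cm/s in this assay, the lowest of the three numbers: the steps of a 10-fold lower number from compound 1 to compound 3 (1.01 log units; beyond the scatter) and a 10-fold lower number from compound 2 to compound 3 (1.01 log units; beyond the scatter) are both large and beyond the scatter. Compound 4 `COc1cccc(CNCCCNc2ccnc3cc(Oc4cccc(N(C)C)c4)ccc23)c1O` is not yet measured. It differs from compound 3 by 3-(dimethylamino)phenoxy in place of 4-cyanobenzyl on an aromatic carbon. Among the measured compounds shown here, the two steps that bear on this change are those into compound 3, each a large fall when a 4-cyanobenzyl replaced a phenyl or 4-(trifluoromethyl)phenyl; compound 4 moves away from the 4-cyanobenzyl, but no measured step covers the 3-(dimethylamino)phenoxy that enters, so a full return to the level of compound 1 and compound 2 cannot be assumed. The step expected is a 3.9-fold higher number from compound 3 to compound 4 (0.59 log units; beyond the scatter), a rise beyond the scatter. Compound 4 is therefore estimated at 90 10^-6 cm/s in this assay, within 35 10^-6 cm/s to 250 10^-6 cm/s.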

Compound 4, apparent permeability in the ADME assay: 317 10^-6 cm/s
Compound 4: middle estimate off by 3.5-fold (0.55 log units), on the low side, and the stated range ends below it.
By their numbers in the ADME assay, from the lowest: compound 3; then compounds 1, 2 and 4 (each within the scatter of the next).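

In the ADME assay, the 3-(dimethylamino)phenoxy group shows that the low number of compound 3 is not general to groups at this aromatic carbon (a 14-fold higher number from compound 3 to compound 4 (1.14 log units; beyond the scatter)), and that a group attached through oxygen with a dimethylamino substituent can stand here with no step beyond the scatter (a 1.3-fold higher number from compound 2 to compound 4 (0.13 log units; within the scatter); a 1.3-fold higher number from compound 1 to compound 4 (0.13 log units; within the scatter)). Among these four compounds, only the 4-cyanobenzyl compound stands apart. In a physicochemical assay for acid dissociation, compound 3 gives 9.47 and compound 4 gives 9.28 (a number 0.19 log units lower from compound 3 to compound 4 (within the scatter)), so the large step in the ADME assay comes without a step beyond the scatter in the physicochemical assay.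

Nothing shown gives a cause for these steps. Still open, on these data alone, is which part of the change matters, as an unsubstituted benzyl or an unsubstituted phenoxy at this carbon would separate the linking atom from the ring substituent.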